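Series notes: aryl substituent swap on the guanidine-urea side chain

The source may hold more compounds than are shown below. What is called first, only, known or untested is meant among the compounds shown, and "the series" means these compounds.

Of the compounds shown here, three of the shared core have been measured so far. Compound 1 `Cc1nc(N)sc1CCCN/C(N)=N/C(=O)NC(C)c1ccc(Br)cc1` gives 55 nM in a functional assay on Right cardiac atrium for agonist activity at histamine H2 receptor (Cavia porcellus), with a stated time of 30 min, in the presence of a further agent that is not named here; on this read-out lower numbers stand for an effect already at smaller amounts and higher numbers for an effect only at larger amounts of compound. Compound 2 `Cc1nc(N)sc1CCCN/C(N)=N/C(=O)NC(C)c1ccc(Cl)cc1` gives 24.6 nM in this assay, and a 2.2-fold lower number from compound 1 to compound 2 (0.35 log units; beyond the scatter). Compound 3 `Cc1nc(N)sc1CCCN/C(N)=N/C(=O)NC(C)c1ccc(OC(F)(F)F)cc1` gives 724 nM in this assay, the highest number of the three: a 13-fold higher number from compound 1 to compound 3 (1.12 log units; beyond the scatter), and a 29-fold higher number from compound 2 to compound 3 (1.47 log units; beyond the scatter).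

Compound 4 `Cc1ccc(C(C)NC(=O)/N=C(\N)NCCCc2sc(N)nc2C)cc1` is not yet measured. Relative to compound 3 the change is methyl in place of trifluoromethoxy on an aromatic carbon. Among the compounds with values here, no methyl analogue has been run, so the bearing steps are the two that remove trifluoromethoxy in reverse: the steps from compound 1 and compound 2 to compound 3 were both large and both raised the number, showing that every substituent tried in place of trifluoromethoxy gives a markedly lower number. Methyl, a one-carbon group without acceptors, is expected to behave like the halogens rather than like trifluoromethoxy, so a large downward step a 12-fold lower number from compound 3 to compound 4 (1.08 log units; beyond the scatter) is expected. The estimate for compound 4 in this assay is 60 nM, with a range from 20 nM to 250 nM.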

Compound 4, half-maximal effective concentration: 22.4 nM
Compound 4: the middle estimate sits 2.7-fold (0.43 log units) above what was measured; low and high end bracket the measured number.
By their numbers in this assay, from the lowest: compounds 4 and 2 (each within the scatter of the next); then compound 1; then compound 3.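

Methyl is the first group at this place that carries no halogen, and the step in this assay with methyl in place of trifluoromethoxy, a 32-fold lower number from compound 3 to compound 4 (1.51 log units; beyond the scatter), shows that a low number here does not depend on a halogen. Methyl in place of chloro, a 1.1-fold lower number from compound 2 to compound 4 (0.04 log units; within the scatter), leaves these two compounds without any order, while methyl in place of bromo gives a modest step, a 2.5-fold lower number from compound 1 to compound 4 (0.39 log units; beyond the scatter), so among the four substituents only trifluoromethoxy stands clearly apart and bromo sits slightly off the methyl and chloro pair. Nothing measured on hand speaks to what lies behind these steps.

Methoxy and trifluoromethyl at this place would show whether the oxygen link or the three fluorines go with the high number of compound 3. Going by these compounds, how an amine, a carboxylic acid or a longer chain such as propyl would fall remains open.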